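A few compounds are considered here, and "the series" means these few. Any claim that something is new, unique, unknown or untested is made for them only; others in the source may bear on it.

Measured so far:
Compound 1 `O=S(=O)(c1c[nH]c2ccc(Cl)cc12)C1CCNCC1`: in a functional assay on the whole organism with Mus musculus as the target, in the writhing test (on this read-out lower numbers stand for an effect already at smaller amounts and higher numbers for an effect only at larger amounts of compound), compound 1 gives 12.5 mg/kg.
Compound 2 `Cc1[nH]c2ccc(Cl)cc2c1SC1CCNCC1`: in this assay compound 2 gives 0.8 mg/kg.

Of these two numbers, compound 2 has the lowest, and compound 1 stands well apart from it, beyond the scatter. Compound 3 `Cc1[nH]c2ccc(C(F)(F)F)cc2c1SC1CCNCC1` differs from compound 2 in one place: trifluoromethyl in place of chloro on an aromatic carbon. For the measured compounds named here, no step between measured compounds shows this exchange, so nothing measured here bears on its size. Compound 3 is expected to stay close to compound 2, with a step of a 1.3-fold higher number from compound 2 to compound 3 (0.10 log units; within the scatter) that is not expected to go beyond the scatter in either direction. For compound 3 the estimate in this assay is 1 mg/kg, within 0.3 mg/kg to 3.5 mg/kg.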

Compound 3, dose for half-maximal effect: 19.4 mg/kg
Compound 3: middle estimate off by 19-fold (1.29 log units), on the low side; measured number outside the range, above it.
By their numbers in this assay, from the lowest: compound 2; then compounds 1 and 3 (each within the scatter of the next).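

In this assay, the aromatic carbon that carries chloro in compound 2 proves sensitive to exchange: trifluoromethyl in place of chloro gives a 24-fold higher number from compound 2 to compound 3 (1.38 log units; beyond the scatter), a large step. This is the first exchange at this position among the compounds shown, and it shows that the low number of compound 2 is not kept when chloro gives way to trifluoromethyl.

With only these two groups compared here, the compounds shown leave open whether fluoro, bromo or methoxy on this carbon would give a number closer to that of compound 2 or compound 3. From the compounds shown here alone, whether a similar step would appear on the core of compound 1 also stays open. Nothing available here explains the size of this step.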